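Amide nitrogen substitution: from compound 3 to compound 4

This account rests on a few compounds, and the source may have more. Where it says the series, first, only, none or still open, it means among the compounds named here.

In an ADME assay on HCT-116 cells (Homo sapiens) for antiproliferative activity (on this read-out lower numbers stand for stronger inhibition and higher numbers for weaker inhibition), compound 1 `COc1ccc(C(N)=O)cc1/C=C/c1ccc(Cl)cc1` gives 7100 nM and compound 2 `COc1ccc(C(N)=O)cc1/C=C\c1ccc(Cl)cc1` gives 29000 nM on the same scale. This pair shows a 4.1-fold higher number from compound 1 to compound 2 (0.61 log units; beyond the scatter) and comes with the fact that compounds 1 and 2 differ only in the configuration as drawn so it bears on the double bond and not on the amide nitrogen. Compound 3 `CNC(=O)c1ccc(OC)c(/C=C/c2ccc(Cl)cc2)c1` gives 16000 nM in this assay and holds the second highest of the three numbers. Its value lies within the scatter of the value of compound 2.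

Compound 4 `COc1ccc(C(=O)NC(CO)CO)cc1/C=C/c1ccc(Cl)cc1` carries 2-hydroxy-1-(hydroxymethyl)ethyl in place of methyl on an amide-type nitrogen, a change counted as 2-hydroxy-1-(hydroxymethyl)ethyl in place of methyl on an amide-type nitrogen in full. For the measured compounds named here, the only measured step at this nitrogen is a 2.3-fold higher number from compound 1 to compound 3 (0.35 log units; beyond the scatter) and it is modest. It covers methyl in place of hydrogen, so it gives no firm direction for a much larger group. No step beyond the scatter is therefore expected in this assay for this change, although the uncertainty is wide. The expected step is a 1.1-fold lower number from compound 3 to compound 4 (0.03 log units; within the scatter) on this estimate. For compound 4 the estimated value is 15000 nM with an expected range from 4000 nM to 50000 nM in this read-out.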

Compound 4, half-maximal inhibitory concentration in the HCT-116 assay: 14000 nM
The estimate for compound 4 lay 1.1-fold (0.03 log units) above the measured number, and the stated range covers the measured number.
By their numbers in the HCT-116 assay, from the lowest: compounds 1, 4, 3 and 2 (each within the scatter of the next, the first and the last beyond it).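

In the HCT-116 assay, the much larger 2-hydroxy-1-(hydroxymethyl)ethyl on the amide-type nitrogen reads the same as methyl within the scatter, at a 1.1-fold lower number from compound 3 to compound 4 (0.06 log units; within the scatter), so this position accepts a chain of this size with no measurable cost against methyl. Against the unsubstituted amide, the picture in the HCT-116 assay is mixed: a 2.0-fold higher number from compound 1 to compound 4 (0.29 log units; within the scatter) stays within the scatter, while a 2.3-fold higher number from compound 1 to compound 3 (0.35 log units; beyond the scatter) lies just beyond it, so the series shows no trend with substituent size at this nitrogen. For the compounds shown here, what the earlier compounds could not show is that this position separates the two read-outs, with the antiproliferative number holding while a physicochemical assay for solubility, read by HPLC, in simulated intestinal fluid, with a stated time of 2 h, tested at 10 mM (on this read-out higher numbers stand for higher solubility and lower numbers for lower solubility), moves well beyond the scatter: the measured solubility of compound 3, 24 ug/mL, and of compound 4, 251 ug/mL, a 10-fold higher number (1.02 log units; beyond the scatter). In the physicochemical assay compound 3 gives 24 ug/mL and compound 4 gives 251 ug/mL.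

On these data alone, it remains open whether the solubility gain needs both hydroxyl groups or would also come with a single 2-hydroxyethyl chain or a plain propyl chain on the same nitrogen. As far as these compounds go, it is also open whether a dimethylaminoethyl chain or a carboxylic acid on this nitrogen would hold the number in the HCT-116 assay in the same way.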